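Epimer step in a cyclic peroxide acid series

This account rests on a few compounds, and the source may have more. Where it says the series, first, only, none or still open, it means among the compounds named here.

compound 1, `C=C1CCCC(C)(C)C1CC[C@]1(C)CC[C@H]([C@@H](C)C(=O)OC)OO1`, gives 3940 nM in a functional assay on SK-MEL-5 cells (Homo sapiens) for inhibition; on this read-out lower numbers stand for stronger inhibition of growth and higher numbers for weaker inhibition of growth
compound 2, `C=C1CCC[C@H]2[C@](C)(CC[C@]3(C)CC[C@@H]([C@@H](C)C(=O)O)OO3)[C@@H](C)CC[C@]12C`, gives 1940 nM in this assay

Going by the values given here, compound 2 has the lower of the two numbers so far; compound 1 sits at a higher number, a gap that lies beyond the scatter. Compound 3, `C=C1CCC[C@H]2[C@](C)(CC[C@]3(C)CC[C@H]([C@@H](C)C(=O)O)OO3)[C@@H](C)CC[C@]12C`, is not yet measured. It differs from compound 2 as follows: the two compounds have the same atoms and bonds and differ only in configuration as drawn: 1 of 7 stereo elements differ; a stereocentre at a saturated ring carbon is drawn S in compound 2 and R in compound 3. Among the compounds with values here, no measured pair shows what such a change does, so no direction is indicated. The step of a 1.3-fold higher number from compound 2 to compound 3 (0.11 log units; within the scatter) is expected to stay within the scatter. Compound 3 is estimated at 2500 nM, within 800 nM to 8000 nM.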

Compound 3, concentration for 50% growth inhibition: 2680 nM
Beside the measured number, compound 3's estimate is 1.1-fold (0.03 log units) below it; low and high end bracket the measured number.
By their numbers in this assay, from the lowest: compounds 2, 3 and 1 (each within the scatter of the next, the first and the last beyond it).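

In this assay the step is a 1.4-fold higher number from compound 2 to compound 3 (0.14 log units; within the scatter), so this read-out does not separate the S and R configurations at this saturated ring carbon. Going by these compounds alone, compounds 1 and 2 offered no pair of this kind, whereas this pair isolates a single stereocentre, with the rest of the structure held constant: the fact that compounds 2 and 3 differ only in the configuration as drawn.

From the compounds shown here alone, whether the two configurations stay equally matched when an amide takes the place of the carboxylic acid remains open. The compounds shown also do not tell whether the other stereocentres tolerate the same change.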